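This account rests on a few compounds, and the source may have more. Where it says the series, first, only, none or still open, it means among the compounds named here.

Working notes on the series, read in a functional assay on MCF7 cells (Homo sapiens) for inhibition, read by colorimetric assay and MTT assay, with a stated time of 72 h; a higher number here means a weaker inhibitor, a lower number a stronger inhibitor. There, compound 1 `COc1ccc2c(c1)-c1cnc(n1C)OCCCCCCCCO2` gives 32000 nM and compound 3 `COc1ccc(C)cc1-c1cnc(OCCCCc2ccccc2)n1C` gives 28000 nM (these two values lie within the scatter of each other only as far as their numbers show). Compound 2 `C=CCCCCOc1ccccc1-c1cnc(OCCC=C)n1C` gives the lowest number of the three (8000 nM), and its gap to each of the others lies beyond the scatter.

The next compound to be read is compound 4 `C=CCCCCOc1ccc(C)cc1-c1cnc(OCCC=C)n1C`, not yet measured. It departs from compound 2 by one change: methyl in place of hydrogen on an aromatic carbon. Within the data shown here, no measured pair isolates this change. Compound 3 also carries a methyl on an aromatic carbon and gives 28000 nM, but it differs from compound 2 in other places as well, so that value says nothing about the methyl alone. With so little to go on, the expectation in this assay is a small step, probably none beyond the scatter, with a slight lean towards a higher number. The expected step is a 1.4-fold higher number from compound 2 to compound 4 (0.14 log units; within the scatter) (an estimate). Compound 4 is estimated at 11000 nM (expected range 4500 nM to 26000 nM).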

Compound 4, half-maximal inhibitory concentration: 53000 nM
Compound 4: middle estimate off by 4.8-fold (0.68 log units), on the low side; the whole stated range lies below it.
By their numbers in this assay, from the lowest: compound 2; then compounds 3, 1 and 4 (each within the scatter of the next).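

In this assay the change of hydrogen to methyl, on an aromatic carbon para to a (hex-5-en-1-yl)oxy group and meta to a large group, gives a 6.6-fold higher number from compound 2 to compound 4 (0.82 log units; beyond the scatter) and so is not a neutral swap on the structure of compound 2. Among these compounds, this is the first pair to isolate the change: a single added carbon, with no ring, no hydrogen-bond donor or acceptor and no net charge, moves the number beyond the scatter, towards weaker inhibition. Nothing available bears on why the step goes this way or reaches this size.

This single pair leaves open whether the loss belongs to methyl alone or would also appear with other groups at this position, such as a fluorine, a chlorine, a methoxy group or an amine. It also leaves open whether the same methyl step would hold with a longer chain in place of the (hex-5-en-1-yl)oxy group, so no rule for this position can yet be drawn beyond compound 2 and compound 4.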